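Working notes on the 3,4-dimethoxyphenyl group of compound 1

The source may report more compounds than this note shows. Statements on the series, on what has been measured and on what is new or still open speak of the compounds shown alone.

- Compound 1 `COc1ccc(C(=O)Nc2ccc(C(=O)/C=C/c3nc(C)c(C)nc3C)cc2)cc1OC`: 1660 nM
- Compound 2 `Cc1nc(C)c(/C=C/C(=O)c2ccc(NC(=O)c3ccccc3)cc2)nc1C`: 990 nM

Both values come from a functional assay on MCF7 cells (Homo sapiens) for antiproliferative activity, read by CCK-8 assay, with a stated time of 72 h; a lower number here means a stronger inhibitor, a higher number a weaker inhibitor. Among the compounds with values here, compound 1 and compound 2 are the only measured compounds, and they lie within the scatter of each other, so neither ranks ahead.

Compound 3 `Cc1ccc(C(=O)Nc2ccc(C(=O)/C=C/c3nc(C)c(C)nc3C)cc2)cc1` keeps the core of compound 1 and differs in a single place: 4-methylphenyl in place of 3,4-dimethoxyphenyl on a carbonyl carbon. This puts 4-methylphenyl in place of 3,4-dimethoxyphenyl on a carbonyl carbon.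

Within the data shown here, one measured step bears on this change: a 1.7-fold lower number from compound 1 to compound 2 (0.22 log units; within the scatter). It replaces the same 3,4-dimethoxyphenyl at the same place, with phenyl as the incoming group. Among the measured compounds shown here, no measured compound carries 4-methylphenyl, and a single step gives thin support. In this assay, no step beyond the scatter is therefore expected, with only a slight lean toward a lower number.

Compound 3 is estimated at 1200 nM, with an expected range from 550 nM to 2600 nM. This estimate means an expected 1.4-fold lower number from compound 1 to compound 3 (0.14 log units; within the scatter).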

Compound 3, half-maximal inhibitory concentration: 1180 nM
Compound 3: the middle estimate sits 1.0-fold (0.01 log units) above what was measured; measured number inside the range.
By their numbers in this assay, from the lowest: compounds 2, 3 and 1 (each within the scatter of the next).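

In this assay, a second replacement of the 3,4-dimethoxyphenyl on the carbonyl carbon, this time by 4-methylphenyl, gives a 1.4-fold lower number from compound 1 to compound 3 (0.15 log units; within the scatter), so two different incoming groups now leave the number within the scatter. Placing methyl in place of hydrogen on an aromatic carbon gives a 1.2-fold higher number from compound 2 to compound 3 (0.08 log units; within the scatter), which adds a comparison the earlier pair could not offer and shows that phenyl and 4-methylphenyl cannot be told apart in this assay. Compound 1, compound 2 and compound 3 therefore show no step beyond the scatter at this position, even with the loss of both oxygen atoms of the 3,4-dimethoxyphenyl, and no measured evidence bears on why the number stays in one band.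

As far as these compounds go, it remains open whether this position responds to anything other than a phenyl ring carrying small groups: an amine or a carboxylic acid on that ring, a longer chain, or a cyclohexyl group in place of the ring could still move the number beyond the scatter. The rest of the core of compound 1 is the same throughout, so what these compounds show says nothing about which part of the structure sets the number.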